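Pyrimidinyl to Pyrazinyl on the Ring Amine: an Estimate

The source may hold more compounds than are shown below. What is called first, only, known or untested is meant among the compounds shown, and "the series" means these compounds.

Compound 1 `Nc1ccccc1NC(=O)c1ccc(CSC(=S)N2CCN(Cc3ccncc3)CC2)cc1`: 18.4% in a functional assay on MGC-803 cells (Homo sapiens) for antiproliferative activity, read by CCK-8 assay, with a stated time of 72 h, tested at 2 uM; a higher number here means a stronger effect of the compound at the concentration tested, a lower number a weaker effect
Compound 2 `Nc1ccccc1NC(=O)c1ccc(CSC(=S)N2CCN(c3ncccn3)CC2)cc1`: 28.4% in this assay

Among the measured compounds shown here, on these two numbers compound 2 stands at the upper end, yet its only neighbour, compound 1, sits within the usual scatter: a number 10 percentage points higher from compound 1 to compound 2 (within the scatter). Compound 3 `Nc1ccccc1NC(=O)c1ccc(CSC(=S)N2CCN(c3cnccn3)CC2)cc1` differs from compound 2 by pyrazin-2-yl in place of pyrimidin-2-yl on an amine nitrogen in a ring. For the measured compounds named here, the one measured step that bears on this place, from compound 1 to compound 2, exchanged a different group at the same ring nitrogen and stayed within the scatter. No change beyond the scatter is therefore expected in this assay, and the estimated step is a number 1.4 percentage points lower from compound 2 to compound 3 (within the scatter). Compound 3 is expected to give 27%, between 14% and 40%.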

Compound 3, a percentage reported as inhibition, at one concentration (the size of the read-out at that concentration, not a potency): 27.1%
Beside the measured number, compound 3's estimate is 0.1 percentage points below it; the measured number falls inside the stated range.
By their numbers in this assay, from the lowest: compounds 1, 3 and 2 (each within the scatter of the next).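

Pyrazin-2-yl and pyrimidin-2-yl have the same atoms joined differently, and in this assay exchanging them gives no step that stands out from the scatter (a number 1.3 percentage points lower from compound 2 to compound 3 (within the scatter)). Pyrazin-2-yl also cannot be told apart from the (pyridin-4-yl)methyl group of compound 1 (a number 8.7 percentage points higher from compound 1 to compound 3 (within the scatter)). No measurement here points to a cause for these results. From the compounds shown here alone, all three groups carry a nitrogen-containing aromatic ring, so it remains open whether a plain phenyl ring, a simple amine or a carboxylic acid at this ring nitrogen would give a step beyond the scatter.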